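A few compounds are considered here, and "the series" means these few. Any claim that something is new, unique, unknown or untested is made for them only; others in the source may bear on it.

Working notes on the series. Three compounds share one core and differ only in the group on the sulfonyl sulfur. Compound 1 `COc1cc2nc(N3CCN(S(=O)(=O)c4ccc([N+](=O)[O-])cc4)CC3)nc(N)c2cc1OC` gives 36000 nM in a functional assay on PC-3 cells (Homo sapiens) for inhibition; on this read-out lower numbers stand for stronger inhibition and higher numbers for weaker inhibition. Compound 2 `COc1cc2nc(N3CCN(S(=O)(=O)c4ccc(OC(F)(F)F)cc4)CC3)nc(N)c2cc1OC` gives 25000 nM in this assay, and compound 3 `COc1cc2nc(N3CCN(S(=O)(=O)c4ccc(S(C)(=O)=O)cc4)CC3)nc(N)c2cc1OC` gives 17000 nM. The measured steps are a 1.4-fold lower number from compound 1 to compound 2 (0.16 log units; within the scatter), a 2.1-fold lower number from compound 1 to compound 3 (0.33 log units; beyond the scatter) and a 1.5-fold lower number from compound 2 to compound 3 (0.17 log units; within the scatter). Compound 3 thus holds the lowest of the three numbers, but only its distance from compound 1 lies beyond the scatter; its number and that of compound 2 are within the scatter of each other.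

The next compound is compound 4 `COc1cc2nc(N3CCN(S(=O)(=O)c4cccc5ccccc45)CC3)nc(N)c2cc1OC`. The change from compound 3 is naphthalen-1-yl in place of 4-(methylsulfonyl)phenyl on a sulfonyl sulfur. None of the three measured steps bears directly on this: each of them exchanges one group on an aromatic carbon for another while keeping the phenyl ring, whereas here the whole group on the sulfonyl sulfur is replaced. Among the compounds with values here, no measured step therefore gives a direction, and the three numbers so far span only a small band. Compound 4 is expected to land near that band, with the estimate for compound 4 in this assay at 20000 nM and a range from 6000 nM to 60000 nM. This estimate means an expected step of a 1.2-fold higher number from compound 3 to compound 4 (0.07 log units; within the scatter), which is not beyond the scatter.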

Compound 4, half-maximal inhibitory concentration: 14000 nM
Compound 4: the middle estimate sits 1.4-fold (0.15 log units) above what was measured; the measured number falls inside the stated range.
By their numbers in this assay, from the lowest: compounds 4, 3, 2 and 1 (each within the scatter of the next, the first and the last beyond it).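

The whole group on the sulfonyl sulfur can be exchanged, not only the substituent on the phenyl ring, with little visible consequence in this assay: naphthalen-1-yl, with 2 six-membered aromatic rings of carbon only and 0 hydrogen-bond acceptors, gives a 1.2-fold lower number from compound 3 to compound 4 (0.08 log units; within the scatter) and a 1.8-fold lower number from compound 2 to compound 4 (0.25 log units; within the scatter), both steps within the scatter. Only the exchange for 4-nitrophenyl lies beyond the scatter, and modestly so, with a 2.6-fold lower number from compound 1 to compound 4 (0.41 log units; beyond the scatter). At this position, therefore, a second aromatic ring and the absence of the methylsulfonyl group leave the number close to those of compound 2 and compound 3, and nothing on hand accounts for this flat response.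

Still open, as far as these compounds go, is whether a group on the sulfonyl sulfur with no aromatic ring, such as a methyl group, a longer alkyl chain or cyclohexyl, would leave the number in the same band. It is equally open whether naphthalen-2-yl, or a phenyl ring carrying an amine or a carboxylic acid, would move the number further than any step seen among these four compounds.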